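This account rests on a few compounds, and the source may have more. Where it says the series, first, only, none or still open, it means among the compounds named here.

In a functional assay on T47D cells (Homo sapiens) for inhibition, read by sulforhodamine B assay, with a stated time of 48 h (a higher number here means a weaker inhibitor of growth, a lower number a stronger inhibitor of growth), compound 2 `CC(=O)OC/C(=C/c1ccc(Cl)cc1Cl)C(=O)c1ccccc1` gives 20000 nM, the highest of the three numbers shown. Compound 3 `O=C(OC/C(=C/c1ccc(Cl)cc1Cl)C(=O)c1ccccc1)c1ccccc1` gives 5400 nM, and compound 1 `CC(=O)OC/C(=C\c1ccc(Cl)cc1Cl)C(=O)c1ccc(Cl)cc1` gives 5200 nM. Compound 4 `CC(=O)OC/C(=C/c1ccc(Cl)cc1Cl)C(=O)c1ccc(Cl)cc1` differs from compound 2 by chloro in place of hydrogen on an aromatic carbon. Going by the values given here, no measured step makes this same change: the single measured step, a 3.7-fold lower number from compound 2 to compound 3 (0.57 log units; beyond the scatter), concerns the carbonyl substituent and not the ring. Compound 1, with 5200 nM, carries the same chloro, but its double bond has the other geometry, so it serves only as a hint that the chloro is compatible with a lower number. Among the compounds with values here, a modest step down is therefore expected, a 2.9-fold lower number from compound 2 to compound 4 (0.46 log units; beyond the scatter), with no measured step to fix its size. Compound 4 is estimated at 7000 nM, between 2500 nM and 20000 nM.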

Compound 4, concentration for 50% growth inhibition: 20000 nM
For compound 4 the middle estimate is 2.9-fold (0.46 log units) below the measured one, within the range that was stated.
By their numbers in this assay, from the lowest: compounds 1 and 3 (each within the scatter of the next); then compounds 2 and 4 (each within the scatter of the next).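

In this assay, chloro in place of hydrogen on this aromatic carbon, with the double bond as drawn in compound 2, gives no change at the digits printed from compound 2 to compound 4 (within the scatter), so the hint taken from compound 1 does not carry over to this geometry. The step of a 3.8-fold higher number from compound 1 to compound 4 (0.59 log units; beyond the scatter) ties the lower number of compound 1 to its double bond and not to the chloro alone: the fact that compounds 1 and 4 differ only in the configuration as drawn

From the compounds shown here alone, whether the other geometry also gives a lower number with a plain phenyl stays open. So does how a methoxy group or an amine in place of chloro would read at this position.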